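From pyridin-2-yl to furan-2-yl on a shared core

The source may hold more compounds than are shown below. What is called first, only, known or untested is meant among the compounds shown, and "the series" means these compounds.

Compound 1 `Clc1ccc(CSc2nnc(-c3ccccc3Cl)o2)cn1`: 13.5 ug/mL
Compound 2 `Clc1ccc(CSc2nnc(-c3ccccn3)o2)cn1`: 12.6 ug/mL

Both values come from a functional assay on SGC-7901 cells (Homo sapiens) for antiproliferative activity, read by MTT assay, with a stated time of 48 h; a lower number here means a stronger inhibitor, a higher number a weaker inhibitor. For the measured compounds named here, with only two compounds measured, compound 2 at 12.6 ug/mL lies within the scatter of compound 1, so neither can be ranked above the other.

Compound 3 `Clc1ccc(CSc2nnc(-c3ccco3)o2)cn1` keeps the shared core and changes one group: furan-2-yl in place of pyridin-2-yl on an aromatic carbon. Going by the values given here, the only measured step that bears on this change swapped one aromatic ring for another at the same place, pyridin-2-yl in place of 2-chlorophenyl, and it came to a 1.1-fold lower number from compound 1 to compound 2 (0.03 log units; within the scatter). One small step is thin evidence, but it gives no reason to expect a large move. The estimated step is a 1.0-fold higher number from compound 2 to compound 3 (0.01 log units; within the scatter), so no direction beyond the scatter is expected. For compound 3 the expected value is 13 ug/mL, with an estimated range from 7 ug/mL to 24 ug/mL.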

Compound 3, half-maximal inhibitory concentration: 14.3 ug/mL
Compound 3: the middle estimate sits 1.1-fold (0.04 log units) below what was measured; the measured number falls inside the stated range.
By their numbers in this assay, from the lowest: compounds 2, 1 and 3 (each within the scatter of the next).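

In this assay the five-membered furan-2-yl ring gives a number within the scatter of the six-membered pyridin-2-yl ring (a 1.1-fold higher number from compound 2 to compound 3 (0.05 log units; within the scatter)) and of 2-chlorophenyl (a 1.1-fold higher number from compound 1 to compound 3 (0.03 log units; within the scatter)). The earlier pair compared only six-membered rings, so compound 3 adds that a change of ring size at this aromatic carbon, with oxygen as the hetero atom in place of nitrogen, also leaves the number within the scatter. No measurement on hand offers an explanation for this result.

The compounds shown carry only aromatic rings at this position, so it remains open whether an amine, a carboxylic acid or a longer chain there would move the number beyond the scatter. They also leave open what a change elsewhere on the shared core would do.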